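The compounds below may be only part of what the source reports. "The series", "measured", "known", "first", "only" and "open" are said of these compounds alone.

Three related compounds have numbers or verdicts in a functional assay on Bel-7402 cells (Homo sapiens) for inhibition, read by MTT assay, with a stated time of 24 h, tested at 10 ug/mL (a higher number here means more inhibition of growth at the concentration tested, a lower number less inhibition of growth), so far. There, compound 1 `O=C(CCCCC1CCSS1)Nc1ccc(Br)cn1` gives 24.5% and compound 2 `O=C(CCCCC(S)CCS)Nc1ccccn1` is recorded as "not active" (no number reported) with no number attached. Going by the values given here, compound 3 `O=C(CCCCC(S)CCS)Nc1ccc(Cl)cn1` gives 17.8% and so lies within the scatter of compound 1, the only other compound with a number.

The next compound, compound 4 `O=C(CCCCC(S)CCS)Nc1ccc(Br)cn1`, differs from compound 3 in one place: bromo in place of chloro on an aromatic carbon, two atoms from the ring nitrogen and para to a large group (bromo in place of chloro on an aromatic carbon). Among the compounds with values here, no measured pair shows this exchange, so its size cannot be read directly from the data. Compound 1 also carries bromo, and its value (24.5%) sits within the scatter of compound 3, so no step beyond the scatter is expected in this assay for this exchange. The expected change (a number 2.2 percentage points higher from compound 3 to compound 4 (within the scatter)) is therefore small. Compound 4 is estimated at 20% (expected range 9% to 32%) and would then remain a weak growth inhibitor at the concentration tested.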

Compound 4, percent growth inhibition at one concentration: 23.2%
Compound 4: the middle estimate sits 3.2 percentage points below what was measured; the measured number falls inside the stated range.
By their numbers in this assay, from the lowest: compounds 3, 4 and 1 (each within the scatter of the next).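

In this assay, going by these compounds alone, bromo in place of chloro on an aromatic carbon, two atoms from the ring nitrogen and para to a large group, gives a number 5.4 percentage points higher from compound 3 to compound 4 (within the scatter) and so provides the first direct reading of this exchange: at this position, the two halogens are not told apart. The second change, on a saturated chain carbon, replaces the group with one five-membered non-aromatic ring by the group with no ring and gives a number 1.3 percentage points lower from compound 1 to compound 4 (within the scatter), so with bromo on the aromatic carbon these two forms are not told apart either. No measurement shown here explains either step.

On these data alone, whether fluoro, methoxy or nitrile on this aromatic carbon, or a longer saturated chain, would give a step beyond the scatter remains open. Compound 2 has no number, so steps involving it cannot be read.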